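Replacing a fluorinated hydrazone arm in a triazolopyrimidine series

The source may hold more compounds than are shown below. What is called first, only, known or untested is meant among the compounds shown, and "the series" means these compounds.

Compound 1 `CCCSc1nc(N/N=C/c2ccccc2F)c2nnn(Cc3ccccc3)c2n1` is tested in a functional assay on MGC-803 cells (Homo sapiens) for antiproliferative activity, read by MTT assay, with a stated time of 72 h; on this read-out higher numbers stand for weaker inhibition and lower numbers for stronger inhibition. In this assay compound 1 gives only a limit, > 64000 nM, and not a number; the data show this with the limit of > 64000 nM in this assay, at which 1 of the 2 values shown sits. A second compound, compound 2 `CCCSc1nc(N/N=C(\C)c2ccccc2O)c2nnn(Cc3ccc(F)cc3)c2n1`, is measured in this assay at 11000 nM, so compound 2 gives a number where compound 1 does not. Among the measured compounds shown here, no single-point step between the two measured compounds is available, so the two values can only be placed side by side.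

Compound 3 `CCCSc1nc(N/N=C(\C)c2ccccc2)c2nnn(Cc3ccccc3)c2n1` has not yet been measured. It differs from compound 1 by a group of 9 heavy atoms (8 carbon, 1 nitrogen; one six-membered aromatic ring of carbon only) in place of a group of 9 heavy atoms (7 carbon, 1 nitrogen, 1 fluorine; one six-membered aromatic ring of carbon only), on a nitrogen on an aromatic ring. Because compound 1 sits at the limit (the limit of > 64000 nM in this assay, at which 1 of the 2 values shown sits), the size of the step to compound 3 cannot be fixed from the measured data; the step is expected to be toward stronger inhibition, though possibly no larger than the scatter, with the expected change written as an at least 2.1-fold lower number from compound 1 to compound 3 (0.32 log units; beyond the scatter). With compound 2 giving a measurable 11000 nM, compound 3 is estimated at 30000 nM, with a range from 8000 nM to 100000 nM.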

Compound 3, half-maximal inhibitory concentration: 25400 nM
Compound 3: middle estimate off by 1.2-fold (0.07 log units), on the high side; the range from low to high includes it.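

The step shows that the group on a nitrogen on an aromatic ring affects activity on these cells: exchanging the fluorine-bearing group for one with an extra carbon and no fluorine gives an at least 2.5-fold lower number from compound 1 to compound 3 (0.40 log units; beyond the scatter) in this assay. The earlier compounds shown here could not show this, as no single-place step linked them, whereas here the groups match in heavy-atom count, in their six-membered aromatic ring of carbon only and in their double bond outside aromatic rings, and still the read-out shifts beyond the usual scatter. The real size of the step remains unknown, and it may be considerably larger than the printed minimum, because compound 1 gives only a limit and not a number: the limit of > 64000 nM in this assay, at which 1 of the 3 values shown sits.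

The fluorine leaves and the extra carbon enters in the same step, so the compounds shown cannot tell which of the two changes accounts for the shift, or whether both contribute. They also do not show how this place would respond to a quite different group, such as an amine or a longer carbon chain.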